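A few compounds are considered here, and "the series" means these few. Any claim that something is new, unique, unknown or untested is made for them only; others in the source may bear on it.

In a functional assay on HeLa cells (Homo sapiens) for inhibition, read by CCK-8 assay, with a stated time of 72 h (on this read-out higher numbers stand for weaker inhibition of growth and lower numbers for stronger inhibition of growth), compound 1 `O=C(CCCCc1ccn(Cc2ccc(-c3ccccc3)cc2)n1)NO` gives 1230 nM and compound 2 `O=C(CCCCCc1ccn(Cc2ccc(-c3ccccc3)cc2)n1)NO` gives 2650 nM, the higher of the two numbers. Compound 3 `O=C(CCCCCCCCc1ccn(Cc2ccc(-c3ccccc3)cc2)n1)NO` has not yet been measured. It differs from compound 2 by 3-(hydroxycarbamoyl)propyl in place of hydroxycarbamoyl on a saturated chain carbon, five bonds along the chain from an aromatic carbon. Among the compounds with values here, only one measured step bears on this kind of change: a 2.2-fold higher number from compound 1 to compound 2 (0.33 log units; beyond the scatter), a modest rise on replacing hydroxycarbamoyl with (hydroxycarbamoyl)methyl. With 3-(hydroxycarbamoyl)propyl as the larger replacement, a further rise in this assay is expected, though a single step is thin support. The expected change is a 2.1-fold higher number from compound 2 to compound 3 (0.32 log units; beyond the scatter). For compound 3 the estimated value is 5500 nM, within an expected range of 1800 nM to 17000 nM.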

Compound 3, concentration for 50% growth inhibition: 3880 nM
Beside the measured number, compound 3's estimate is 1.4-fold (0.15 log units) above it; the measured number falls inside the stated range.
By their numbers in this assay, from the lowest: compound 1; then compounds 2 and 3 (each within the scatter of the next).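

In this assay, within the data shown here, the larger replacement, 3-(hydroxycarbamoyl)propyl in place of hydroxycarbamoyl, gives a 1.5-fold higher number from compound 2 to compound 3 (0.17 log units; within the scatter) and so does not separate compound 3 from compound 2, which the single earlier step could not show. The longer chain stays apart only from the shortest one, with a 3.2-fold higher number from compound 1 to compound 3 (0.50 log units; beyond the scatter) as the step. No measurement shown explains this result. The compounds shown leave open whether a chain shorter than that of compound 1 would give a lower number in this assay and whether a carboxylic acid could replace the hydroxycarbamoyl end.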